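Replacing a furanylmethyl arm with an isopropylcarbonyl group

The source may report more compounds than this note shows. Statements on the series, on what has been measured and on what is new or still open speak of the compounds shown alone.

In an assay on HEK293 cells for agonist activity at Toll-like receptor 8 (Homo sapiens), read by a luciferase reporter, with a stated time of 6 h (a higher number here means that more compound is needed for the effect, a lower number that less compound is needed), compound 1 `CCCCNc1nc(N)nc2c1CN(Cc1ccccc1)CC2` gives 0.06 uM and compound 2 `CCCCNc1nc(N)nc2c1CN(Cc1ccco1)CC2` gives 0.08 uM. Among the compounds with values here, compound 2 has the higher of the two numbers, but the only measured step, a 1.3-fold higher number from compound 1 to compound 2 (0.12 log units; within the scatter), falls within the scatter, so the two compounds are indistinguishable on this evidence. Compound 3 `CCCCNc1nc(N)nc2c1CN(C(=O)C(C)C)CC2` is not yet measured. It differs from compound 2 in this way: isopropylcarbonyl in place of (furan-2-yl)methyl on an amine nitrogen in a ring. Within the data shown here, no measured step bears directly on this change; the one available step exchanged one aromatic ring for another on the same arm and left the carbonyl and the loss of the ring untested. Because a 1.3-fold higher number from compound 1 to compound 2 (0.12 log units; within the scatter) was small, the aromatic ring itself seems not decisive, but this says nothing about a carbonyl on the ring nitrogen. Compound 3 is therefore expected to give 0.3 uM, within 0.08 uM to 2 uM, a step of a 3.8-fold higher number from compound 2 to compound 3 (0.57 log units; beyond the scatter) with wide uncertainty.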

Compound 3, minimum effective concentration: 1.6 uM
Beside the measured number, compound 3's estimate is 5.3-fold (0.73 log units) below it, and the stated range covers the measured number.
By their numbers in this assay, from the lowest: compounds 1 and 2 (each within the scatter of the next); then compound 3.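

In this assay the group on the amine nitrogen in a ring proves to matter: isopropylcarbonyl in place of (furan-2-yl)methyl gives a 20-fold higher number from compound 2 to compound 3 (1.30 log units; beyond the scatter) and isopropylcarbonyl in place of benzyl gives a 27-fold higher number from compound 1 to compound 3 (1.43 log units; beyond the scatter), both beyond the scatter, whereas the exchange of one aromatic ring for the other stayed within it. So this position does not accept every group alike, and the earlier pair could not show this, as both of its arms carry an aromatic ring on a saturated chain carbon. No evidence at hand accounts for the size of these steps.

The compounds shown leave open whether the higher number goes with the entering carbonyl or with the lost ring, since both changes arrive together. A benzoyl group on that nitrogen would pair a carbonyl with an aromatic ring, and an isobutyl group would give a branched chain without a carbonyl.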